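The source may report more compounds than this note shows. Statements on the series, on what has been measured and on what is new or still open speak of the compounds shown alone.

Measured compounds, each with its read-out in a functional assay on MDA-MB-468 cells (Homo sapiens) for inhibition, read by sulforhodamine B assay, with a stated time of 48 h, tested at 10 uM; a lower number here means less inhibition, a higher number more inhibition at the concentration tested (going by the name of the read-out):
compound 1 `COc1ccc(-c2cn3ccnc3c(-c3ccc4ncn(C5CCCCC5)c4c3)n2)cc1`, 97.4%
compound 2 `c1ccc2c(-c3cn4ccnc4c(-c4ccc5ncn(C6CCCCC6)c5c4)n3)cccc2c1`, 10.4%
compound 3 `c1cn2cc(-c3ccsc3)nc(-c3ccc4ncn(C5CCCCC5)c4c3)c2n1`, 21.8%

Compound 3 stands second highest of the three numbers: it sits a number 11.4 percentage points higher from compound 2 to compound 3 (beyond the scatter), yet far beneath compound 1. Compound 4 `CC(=O)c1ccc(-c2cn3ccnc3c(-c3ccc4ncn(C5CCCCC5)c4c3)n2)cc1` differs from compound 3 by 4-acetylphenyl in place of thiophen-3-yl on an aromatic carbon. Among the compounds with values here, two measured steps bear on this change: a number 75.6 percentage points lower from compound 1 to compound 3 (beyond the scatter) and a number 11.4 percentage points higher from compound 2 to compound 3 (beyond the scatter). Within the data shown here, the one analogue carrying a six-membered aromatic ring of carbon only with a single substituent, compound 1, stands far above the thiophen-3-yl of compound 3, whereas the naphthalen-1-yl of compound 2 falls below it. Among the measured compounds shown here, since 4-acetylphenyl again brings such a ring, a large upward step is expected, a number 58.2 percentage points higher from compound 3 to compound 4 (beyond the scatter), although no acetyl analogue has been measured. Compound 4 is therefore estimated at 80%, between 45% and 98%.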

Compound 4, a percentage reported as inhibition, at one concentration (the size of the read-out at that concentration, not a potency) in the MDA-MB-468 assay: 0.73%
Beside the measured number, compound 4's estimate is 79.3 percentage points above it; the whole stated range lies above it.
By their numbers in the MDA-MB-468 assay, from the lowest: compounds 4 and 2 (each within the scatter of the next); then compound 3; then compound 1.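

In the MDA-MB-468 assay, a six-membered aromatic ring of carbon only on this aromatic carbon proves insufficient for a high number: compound 4 gives 0.73%, and with acetyl in place of methoxy, the read-out shows a number 96.7 percentage points lower from compound 1 to compound 4 (beyond the scatter). The 4-acetylphenyl group also gives a number 21.1 percentage points lower from compound 3 to compound 4 (beyond the scatter), while a number 9.7 percentage points lower from compound 2 to compound 4 (within the scatter), which leaves the 4-methoxyphenyl of compound 1 alone at the top of these four compounds. In a physicochemical assay for lipophilicity, using the shake flask method, in phosphate buffer, measured as octanol-water partition, with a stated time of 85 min, at pH 7.4 (a higher number here means a more lipophilic compound, a lower number a more polar compound), compound 3 gives 1.81 and compound 4 gives 2.06, two values within the scatter of each other. Nothing given here accounts for this loss. Still open, going by these compounds, is whether hydroxy, an amine or a carboxylic acid in place of the methoxy would keep the high number.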